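One phenyl group exchanged, one number still to come

This account rests on a few compounds, and the source may have more. Where it says the series, first, only, none or still open, it means among the compounds named here.

Among the measured compounds shown here, in a physicochemical assay for lipophilicity (on this read-out higher numbers stand for higher lipophilicity and lower numbers for lower lipophilicity), compound 1 `C[C@H]1CC[C@@H]2[C@@H](OC(=O)[C@]23CC(c2ccc(F)cc2)N(c2ccccc2)O3)[C@]2(C)C(=O)C=C[C@@]12O` gives 3.35 and compound 2 `Cc1ccccc1C1C[C@@]2(ON1c1ccccc1)C(=O)O[C@@H]1[C@H]2CC[C@H](C)[C@]2(O)C=CC(=O)[C@@]12C` gives 3.64, so compound 2 stands level with its only neighbour within the scatter. Compound 3 `C[C@H]1CC[C@@H]2[C@@H](OC(=O)[C@]23CC(c2c(Cl)cccc2Cl)N(c2ccccc2)O3)[C@]2(C)C(=O)C=C[C@@]12O` keeps the shared core and carries 2,6-dichlorophenyl in place of 2-methylphenyl on a saturated ring carbon. For the measured compounds named here, the one measured step at this carbon is a number 0.29 log units higher from compound 1 to compound 2 (within the scatter) and it also exchanged one substituted phenyl for another. Given that small step, only a modest rise is expected in this assay, estimated as a number 0.36 log units higher from compound 2 to compound 3 (beyond the scatter) for this change. Compound 3 is estimated at 4 with a range from 3.55 to 4.45 expected.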

Compound 3, partition coefficient: 4.45
The estimate for compound 3 lay 0.45 log units below the measured number; measured number inside the range.
By their numbers in this assay, from the lowest: compounds 1 and 2 (each within the scatter of the next); then compound 3.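

Unlike the earlier exchange at this saturated ring carbon, this one clears the scatter in this assay: 2,6-dichlorophenyl in place of 2-methylphenyl gives a number 0.81 log units higher from compound 2 to compound 3 (beyond the scatter), and 2,6-dichlorophenyl in place of 4-fluorophenyl gives a number 1.10 log units higher from compound 1 to compound 3 (beyond the scatter). The choice of substituted phenyl at this carbon can therefore shift the number well beyond the scatter. No supporting data explain the size of these steps. On these data alone, all three compounds carry a substituted phenyl here, so the effect of an amine or a carboxylic acid at this carbon remains open. Also open, as far as these compounds go, is what 2-chlorophenyl, with a single chlorine, would give.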